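A few compounds are considered here, and "the series" means these few. Any claim that something is new, unique, unknown or untested is made for them only; others in the source may bear on it.

Measured in a functional assay on MCF7 cells (Homo sapiens) for cytotoxicity, read by MTT assay, with a stated time of 96 h; a lower number here means a stronger inhibitor, a higher number a weaker inhibitor:
compound 1 `COc1cc(C(=O)c2cn(-c3cccc(N)c3)cc2-c2ccc([N+](=O)[O-])cc2)cc(OC)c1OC` gives 110 nM;
compound 2 `COc1cc(C(=O)c2cn(-c3cccc(N)c3)cc2-c2cccc(N)c2)cc(OC)c1OC` gives 60 nM;
compound 3 `COc1cc(C(=O)c2cn(-c3ccc(F)cc3)cc2-c2ccc([N+](=O)[O-])cc2)cc(OC)c1OC` gives 240 nM.

Compound 3 differs from compound 1 in 4-fluorophenyl in place of 3-aminophenyl on an aromatic nitrogen, which brought a 2.2-fold higher number from compound 1 to compound 3 (0.34 log units; beyond the scatter). Compound 2 differs from compound 1 in 3-aminophenyl in place of 4-nitrophenyl on an aromatic carbon, which brought a 1.8-fold lower number from compound 1 to compound 2 (0.26 log units; within the scatter).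

Compound 4 `COc1cc(C(=O)c2cn(-c3ccc(F)cc3)cc2-c2cccc(N)c2)cc(OC)c1OC` is not yet measured. It differs from compound 3 in 3-aminophenyl in place of 4-nitrophenyl on an aromatic carbon. This is the same kind of change as that from compound 1 to compound 2, though not the same: around the place, the ring atom two ring bonds away bears a 4-fluorophenyl group in compound 3 but a 3-aminophenyl group in compound 1.

The expected step is a 1.8-fold lower number from compound 3 to compound 4 (0.27 log units; within the scatter), resting on the earlier step of a 1.8-fold lower number from compound 1 to compound 2 (0.26 log units; within the scatter), which the same kind of change produced. For compound 4 the expected value is 130 nM.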

Compound 4, half-maximal inhibitory concentration: 53 nM
For compound 4 the middle estimate is 2.5-fold (0.39 log units) above the measured one, and the stated range ends above it.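

In this assay, 3-aminophenyl in place of 4-nitrophenyl on an aromatic carbon brings a 4.5-fold lower number from compound 3 to compound 4 (0.66 log units; beyond the scatter), and this step does not differ from its counterpart on the other core beyond the scatter: the same change on two cores in this assay, a 1.8-fold lower number (0.26 log units; within the scatter) from compound 1 to compound 2 and a 4.5-fold lower number (0.66 log units; beyond the scatter) from compound 3 to compound 4, 2.5-fold (0.39 log units) apart, within the scatter of two such steps. With 4-fluorophenyl in place of 3-aminophenyl on an aromatic nitrogen, the new step is a 1.1-fold lower number from compound 2 to compound 4 (0.05 log units; within the scatter), and it too agrees with its counterpart within the scatter: the same change on two cores in this assay, a 2.2-fold higher number (0.34 log units; beyond the scatter) from compound 1 to compound 3 and a 1.1-fold lower number (0.05 log units; within the scatter) from compound 2 to compound 4, 2.5-fold (0.39 log units) apart, within the scatter of two such steps. Both changes therefore carry across these two cores as far as the scatter can tell, but two pairs do not fix the size of either step, nor show that the steps would hold on any further core.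

The compounds shown leave open how a carboxylic acid or a dimethylamino group in place of the amine of the 3-aminophenyl group would compare.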